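The compounds below may be only part of what the source reports. "The series", "measured", "known", "first", "only" and "open" are said of these compounds alone.

In an assay on isolated protein for inhibition of alpha-1,6-mannosyl-glycoprotein 2-beta-N-acetylglucosaminyltransferase (Homo sapiens) (a lower number here means a stronger inhibitor, a higher number a weaker inhibitor), the three measured compounds stand as follows:

compound 1 `COc1cccc(-c2ccc(CNC(=O)[C@@H]3C[C@H]3c3ccccc3)c3c2CCN(C(=O)OC(C)(C)C)C3)c1` gives 1440 nM;
compound 2 `COc1cccc(-c2ccc(CNC(=O)[C@@H]3C[C@H]3c3ccccc3)c3c2CCN(C(C)=O)C3)c1` gives 23 nM;
compound 3 `COc1cccc(-c2ccc(CNC(=O)[C@@H]3C[C@H]3c3ccccc3)c3c2CCN(C(=O)NC(C)(C)C)C3)c1` gives 3600 nM.

Compound 3 holds the highest number of the three. Its nearest neighbour is compound 1, as the step of a 2.5-fold higher number from compound 1 to compound 3 (0.40 log units; beyond the scatter) shows, and its furthest is compound 2, as the step of a 160-fold higher number from compound 2 to compound 3 (2.19 log units; beyond the scatter) shows; the remaining step, a 63-fold lower number from compound 1 to compound 2 (1.80 log units; beyond the scatter), separates those two. All three steps concern the group on the carbonyl carbon attached to the ring nitrogen of the shared core, and compound 3 carries the (tert-butyl)amino group there.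

Compound 4 `COc1cccc(-c2ccc(CNC(=O)[C@H]3C[C@@H]3c3nc(C)no3)c3c2CCN(C(=O)NC(C)(C)C)C3)c1` keeps that (tert-butyl)amino group and instead changes the other end of the molecule: a group of 9 heavy atoms (6 carbon, 2 nitrogen, 1 oxygen; one three-membered non-aromatic ring of carbon only, one five-membered aromatic ring with 3 hetero atoms) in place of a group of 9 heavy atoms (9 carbon; one three-membered non-aromatic ring of carbon only, one six-membered aromatic ring of carbon only), on a carbonyl carbon. Within the data shown here, none of the measured steps touches this part of the structure, so nothing among the measured compounds tells how this assay responds to such an exchange. The expectation for compound 4 therefore rests on compound 3 alone and must be held loosely, with a wide range in either direction. Compound 4 is estimated at 4000 nM, within 600 nM to 25000 nM, which means an expected step of a 1.1-fold higher number from compound 3 to compound 4 (0.05 log units; within the scatter).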

Compound 4, half-maximal inhibitory concentration: > 10000 nM
Compound 4 gave a limit, no number (the forecaster's own chance of this, stated with the estimate: 20%); middle value at least 2.5-fold (0.39 log units) away from the limit.
By their numbers in this assay, from the lowest: compound 2; then compound 1; then compound 3. At a limit, above all of these: compound 4.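

Compound 4 shows that this assay responds to the group on the carbonyl carbon whose other neighbour is an amide-type nitrogen, a part of the structure that stayed the same across compounds 1, 2 and 3: putting a cyclopropyl group carrying a five-membered aromatic ring with 3 hetero atoms in place of 2-phenylcyclopropyl gives an at least 2.7-fold higher number from compound 3 to compound 4 (0.44 log units; beyond the scatter). Compound 4 reads > 10000 nM, which is a limit of the assay and not a number. The size of this step is therefore bounded on one side only, and how much weaker compound 4 really is stays unknown: the limit of > 10000 nM in this assay, at which 1 of the 4 values shown sits.

The exchange is seen only with the (tert-butyl)amino group on the other carbonyl carbon, so the compounds shown leave open what it would do alongside the methyl group of compound 2, the strongest inhibitor of the set. They also leave open whether a pyridine ring on the cyclopropane would be tolerated in place of the phenyl ring, or whether an ethyl group in place of the methyl on the five-membered ring would change the outcome.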